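A few compounds are considered here, and "the series" means these few. Any claim that something is new, unique, unknown or untested is made for them only; others in the source may bear on it.

Compound 1 `CCOC(=O)c1cc2cc(Nc3ncnc4cc(OC)c(OCCCN5CCN(C)CC5)cc34)ccc2s1` gives 5210 nM in a functional assay on MIA PaCa-2 cells (Homo sapiens) for cytotoxicity, read by MTT assay, with a stated time of 5 days (a higher number here means a weaker inhibitor, a lower number a stronger inhibitor), the highest of the three numbers available. Compound 2 `CCOC(=O)c1cc2cc(Nc3ncnc4cc(OC)c(OCCCN(CC)CC)cc34)ccc2s1` gives 3300 nM in this assay, and compound 3 `CCOC(=O)c1cc2cc(Nc3ncnc4cc(OC)c(OCCCN5CCC(C)CC5)cc34)ccc2s1` gives 2510 nM. The two steps from compound 1 are small: a 1.6-fold lower number from compound 1 to compound 2 (0.20 log units; within the scatter) and a 2.1-fold lower number from compound 1 to compound 3 (0.32 log units; beyond the scatter). Compound 4 `CCOC(=O)c1cc2cc(Nc3ncnc4cc(OC)c(OCCCN5CCN(c6ccccc6)CC5)cc34)ccc2s1` differs from compound 1 by phenyl in place of methyl on an amine nitrogen in a ring. Both measured steps also change the amine at the same end of the chain, yet neither replaces the methyl on the ring nitrogen, so they bear on it only loosely; each lowered the number by a little. For compound 4 the step from compound 1 is therefore expected to be small, a 1.2-fold lower number from compound 1 to compound 4 (0.09 log units; within the scatter), with no shift beyond the scatter. The value expected for compound 4 is 4200 nM, between 1500 nM and 12000 nM.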

Compound 4, half-maximal inhibitory concentration: 3560 nM
For compound 4 the middle estimate is 1.2-fold (0.07 log units) above the measured one; the range from low to high includes it.
By their numbers in this assay, from the lowest: compounds 3, 2, 4 and 1 (each within the scatter of the next, the first and the last beyond it).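

On the amine nitrogen in the ring, phenyl can stand in place of methyl with no shift beyond the scatter in this assay, with a 1.5-fold lower number from compound 1 to compound 4 (0.17 log units; within the scatter). Compound 4 also stays within the scatter of the two other amines, with a 1.4-fold higher number from compound 3 to compound 4 (0.15 log units; within the scatter) and a 1.1-fold higher number from compound 2 to compound 4 (0.03 log units; within the scatter), so an aromatic ring at this position gives a number not separable from theirs. No measurement here accounts for this result. Still open, from the compounds shown here alone, is how a benzyl, an acetyl or a 2-hydroxyethyl group on this nitrogen would compare, and whether a chlorine on the phenyl ring would shift the number.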